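From Fluoro to Trifluoromethyl on a Shared Core

The compounds below may be only part of what the source reports. "The series", "measured", "known", "first", "only" and "open" are said of these compounds alone.

Of the compounds shown here, three built on one shared core have been measured in an assay on cell membranes for displacement of a labelled ligand from Neuronal acetylcholine receptor; alpha4/beta2 (Rattus norvegicus); on this read-out higher numbers stand for weaker inhibition and lower numbers for stronger inhibition. Compound 1 `Oc1ccc(Nc2cncc(N3CC4CC(C3)N4)c2)cc1` gives 0.342 nM. Compound 2 `Clc1ccc(Nc2cncc(N3CC4CC(C3)N4)c2)cc1` gives 0.118 nM. Compound 3 `Fc1ccc(Nc2cncc(N3CC4CC(C3)N4)c2)cc1` gives 0.091 nM, the lowest of the three numbers, although its gap to compound 2 lies within the scatter, so those two cannot be ranked against each other.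

The measured steps show that replacing hydroxy with a halogen shifts the number: a 2.9-fold lower number from compound 1 to compound 2 (0.46 log units; beyond the scatter) and a 3.8-fold lower number from compound 1 to compound 3 (0.57 log units; beyond the scatter). Exchanging one halogen for another does not: a 1.3-fold lower number from compound 2 to compound 3 (0.11 log units; within the scatter).

Compound 4 `FC(F)(F)c1ccc(Nc2cncc(N3CC4CC(C3)N4)c2)cc1` differs from compound 3 by trifluoromethyl in place of fluoro on an aromatic carbon. Among the compounds with values here, no measured step replaces a halogen with trifluoromethyl, so the only guidance is that the changes already seen at this place were modest or within the scatter. A large step is therefore not expected; if anything, the number is estimated to drift slightly upward, as a 2.2-fold higher number from compound 3 to compound 4 (0.34 log units; beyond the scatter). Compound 4 is expected to give about 0.2 nM in this assay, with a range from 0.06 nM to 0.7 nM.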

Compound 4, inhibition constant: 0.373 nM
Estimate against measurement, compound 4: 1.9-fold (0.27 log units) below; the measured number falls inside the stated range.
By their numbers in this assay, from the lowest: compounds 3 and 2 (each within the scatter of the next); then compounds 1 and 4 (each within the scatter of the next).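

In this assay the place on the aromatic ring para to a large group turns out to distinguish among groups that carry no hydrogen-bond donors, something the two halogens alone could not show: trifluoromethyl gives a number clearly apart from fluoro (a 4.1-fold higher number from compound 3 to compound 4 (0.61 log units; beyond the scatter)) and from chloro (a 3.2-fold higher number from compound 2 to compound 4 (0.50 log units; beyond the scatter)). Both steps lie beyond the scatter, so the earlier impression that exchanges among these small substituents make little difference holds for fluoro and chloro but does not extend to trifluoromethyl. Within the data shown here, the step from hydroxy (a 1.1-fold higher number from compound 1 to compound 4 (0.04 log units; within the scatter)) lies within the scatter, so these four compounds fall into two pairs, compounds 2 and 3 on the lower side and compounds 1 and 4 on the higher, with no ranking inside either pair.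

Nothing available explains why trifluoromethyl parts from the halogens, or why it sits with hydroxy. From the compounds shown here alone, whether a methoxy group, an amine or a nitrile at this place would fall with compounds 2 and 3 or with compounds 1 and 4 remains open.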